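A few compounds are considered here, and "the series" means these few. Any claim that something is new, unique, unknown or untested is made for them only; others in the source may bear on it.

Compound 1 `COc1cc(-c2ccnc3cc(-c4c[nH]c5ccccc45)nn23)cc(OC)c1OC` is the weakest-looking member of the three measured compounds: in a functional assay on MCF7 cells (Homo sapiens) for inhibition, read by CCK-8 assay, with a stated time of 48 h (on this read-out higher numbers stand for weaker inhibition and lower numbers for stronger inhibition), compound 1 gives 85 nM, the highest number of the set. Compound 2 `COc1cc(-c2ccnc3cc(-c4ccc(C)cc4)nn23)cc(OC)c1OC` carries 4-methylphenyl and gives 47 nM, so that the step of a 1.8-fold lower number from compound 1 to compound 2 (0.26 log units; within the scatter) stays within the scatter. Compound 3 `COc1cc(-c2ccnc3cc(-c4ccc5c(ccn5C)c4)nn23)cc(OC)c1OC` carries 1-methyl-1H-indol-5-yl and gives 3 nM, a clearly lower number: a 28-fold lower number from compound 1 to compound 3 (1.45 log units; beyond the scatter) and a 16-fold lower number from compound 2 to compound 3 (1.19 log units; beyond the scatter) are both large.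

Compound 4 `COc1cc(-c2ccnc3cc(-c4ccc5cc[nH]c5c4)nn23)cc(OC)c1OC` has not yet been measured. It differs from compound 1 in one place: 1H-indol-6-yl in place of 1H-indol-3-yl on an aromatic carbon. Among the compounds with values here, two measured steps bear on this. The swap to 4-methylphenyl in compound 2 changed little, whereas the swap to 1-methyl-1H-indol-5-yl in compound 3 brought a large drop in the number. Compound 4 keeps a two-ring indole, as compound 3 does, but with the hydrogen-bond donor retained, as in compound 1, so the size of the drop is uncertain. He therefore expects a lower number for compound 4, with a step of a 7.1-fold lower number from compound 1 to compound 4 (0.85 log units; beyond the scatter) from compound 1, because compound 3 reached 3 nM with a closely related indole. His estimate for compound 4 is 12 nM, within a range from 3 nM to 45 nM.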

Compound 4, half-maximal inhibitory concentration: 23 nM
For compound 4 the middle estimate is 1.9-fold (0.28 log units) below the measured one; the measured number falls inside the stated range.
By their numbers in this assay, from the lowest: compound 3; then compound 4; then compounds 2 and 1 (each within the scatter of the next).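

Compound 4 has the same atoms as compound 1, and the indole is only joined through a different ring carbon, so in this assay the attachment point alone accounts for a 3.7-fold lower number from compound 1 to compound 4 (0.57 log units; beyond the scatter); the earlier compounds could not show this, as compound 3 also carries a methyl on the indole nitrogen. The unmethylated 1H-indol-6-yl group gives only a 2.0-fold lower number from compound 2 to compound 4 (0.31 log units; beyond the scatter), a step just beyond the scatter, while a 7.7-fold higher number from compound 3 to compound 4 (0.88 log units; beyond the scatter) shows that moving the attachment point on the plain indole does not by itself reach the low number of the 1-methyl-1H-indol-5-yl group. Nothing shown here gives a measured reason for any of these steps.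

As far as these compounds go, how much of the gap between compound 3 and compound 4 belongs to the methyl and how much to the attachment point stays open, and a 1H-indol-5-yl or 1-methyl-1H-indol-6-yl group would be the comparison that separates the two. Also open, from the compounds shown here alone, is how a longer chain such as ethyl on the indole nitrogen, or an amine in place of the indole at this position, would read.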